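Compound 3 to compound 4: swapping the side chain

The compounds below may be only part of what the source reports. "The series", "measured", "known", "first", "only" and "open" are said of these compounds alone.

In an ADME assay on L1210/0 cells (Mus musculus) for cytotoxicity, with a stated time of 48 h (a lower number here means a stronger inhibitor, a higher number a weaker inhibitor), compound 1 `O=c1[nH]c(=O)n([C@H]2C[C@H](O)[C@@H](CO)O2)cc1CO` gives 9180 nM and compound 2 `O=c1[nH]c(=O)n([C@H]2C[C@H](O)[C@@H](CO)O2)cc1[N+](=O)[O-]` gives 130 nM. Compound 3 `CCCC#Cc1cn([C@H]2C[C@H](O)[C@@H](CO)O2)c(=O)[nH]c1=O` gives > 200000 nM, which is a limit and not a number. For compound 3 this is the limit of > 200000 nM in this assay, at which 1 of the 3 values shown sits.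

Compound 4 `O=c1[nH]c(=O)n([C@H]2C[C@H](O)[C@@H](CO)O2)cc1/C=C/Cl` differs from compound 3 as follows: 2-chloroethenyl in place of pent-1-yn-1-yl on an aromatic carbon.

All three measured steps are large and beyond the scatter: a 71-fold lower number from compound 1 to compound 2 (1.85 log units; beyond the scatter), an at least 21-fold higher number from compound 1 to compound 3 (1.33 log units; beyond the scatter) and an at least 1500-fold higher number from compound 2 to compound 3 (3.18 log units; beyond the scatter). None of them involves 2-chloroethenyl. Compound 4 also carries a carbon chain with a multiple bond, so it is expected to keep part of the rise seen in an at least 21-fold higher number from compound 1 to compound 3 (1.33 log units; beyond the scatter). A moderate move to a lower number is expected in this assay, and another limit reading remains possible.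

The expected step is an at least 3.3-fold lower number from compound 3 to compound 4 (0.52 log units; beyond the scatter).

For compound 4 the estimated value is 60000 nM, with an expected range of 10000 nM to 200000 nM.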

Compound 4, half-maximal inhibitory concentration: > 200000 nM
Compound 4: a limit, no number; the forecaster's own chance of this, stated with the estimate: 40%; middle value at least 3.3-fold (0.52 log units) away from the limit.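

Compound 4 gives a limit and not a number in this assay, the second carbon chain with a multiple bond at this position to do so: the limit of > 200000 nM in this assay, at which 2 of the 4 values shown sit.

2-Chloroethenyl gives an at least 1500-fold higher number from compound 2 to compound 4 (3.18 log units; beyond the scatter) and an at least 21-fold higher number from compound 1 to compound 4 (1.33 log units; beyond the scatter), so among the compounds shown the rise is not confined to pent-1-yn-1-yl. The step between compound 3 and compound 4 cannot be read.

From the compounds shown here alone, how far compound 3 and compound 4 lie past the limit remains open. Also open, going by these compounds, is whether an ethyl group or an amine on this aromatic carbon would give a number nearer that of compound 2 or of compound 1.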